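A few compounds are considered here, and "the series" means these few. Any claim that something is new, unique, unknown or untested is made for them only; others in the source may bear on it.

Of the two compounds measured in a functional assay on SH-SY5Y cells (Homo sapiens) for antiproliferative activity, with a stated time of 24 h, tested at 50 ug/mL (a lower number here means a weaker effect, a higher number a stronger effect of the compound at the concentration tested), compound 2 `Cc1cc2c(c(=O)o1)C=C(C(C)C)C(CC(C)C)O2` stands highest: compound 2 gives 95.7%, whereas compound 1 `CCCCCCCCC1C=Cc2c(cc(C)oc2=O)O1` gives 83.3%, a gap beyond the scatter. Compound 3 `Cc1cc2c(c(=O)o1)C=C(c1ccccc1)C(CC(C)C)O2` awaits measurement. It differs from compound 2 in one place: phenyl in place of isopropyl on a double-bonded ring carbon. Among the compounds with values here, no pair of measured compounds shows what this exchange does, so the expected step rests only on the high standing of compound 2. The step is expected to be a small loss, hardly beyond the scatter, a number 7.7 percentage points lower from compound 2 to compound 3 (within the scatter). Compound 3 is therefore estimated at 88%, within a range from 70% to 99%.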

Compound 3, a percentage reported as inhibition, at one concentration (the size of the read-out at that concentration, not a potency): 81.7%
Beside the measured number, compound 3's estimate is 6.3 percentage points above it; the range from low to high includes it.
By their numbers in this assay, from the lowest: compounds 3 and 1 (each within the scatter of the next); then compound 2.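

In this assay, this double-bonded ring carbon proves sensitive to the group it carries: phenyl in place of isopropyl gives a number 14 percentage points lower from compound 2 to compound 3 (beyond the scatter), a loss beyond the scatter. The effect nevertheless remains substantial with the aromatic ring at this position, so the exchange weakens the read-out without abolishing it. Nothing available explains this step. From the compounds shown here alone, whether a hydrogen, a methyl group or a cyclohexyl ring here would stay closer to compound 2 remains open. So does the effect of an amine or a carboxylic acid on the phenyl ring of compound 3.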